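This account rests on a few compounds, and the source may have more. Where it says the series, first, only, none or still open, it means among the compounds named here.

The three compounds measured so far:

Compound 1, `Fc1cccc(CSc2nc(-c3ccc(Br)cc3)cc(-c3ccc(Br)cc3)n2)c1`, gives 19000 nM in an assay on isolated protein for inhibition of Alpha glucosidase (Homo sapiens), read by spectrophotometry, with stated times of 15 min and 30 min; a lower number here means a stronger inhibitor, a higher number a weaker inhibitor.
Compound 2, `Clc1ccccc1CSc1nc(-c2ccc(Br)cc2)cc(-c2ccc(Br)cc2)n1`, gives 19000 nM in this assay.
Compound 3, `Clc1ccc(CSc2nc(-c3ccc(Br)cc3)cc(-c3ccc(Br)cc3)n2)cc1`, gives 19000 nM in this assay.

Compound 2 stands level with the other two: no change at the digits printed from compound 1 to compound 2 (within the scatter), no change at the digits printed from compound 2 to compound 3 (within the scatter), and no change at the digits printed from compound 1 to compound 3 (within the scatter). These three differ only in the halogenated benzyl group bound through sulfur, and none of those exchanges moved the number beyond the scatter.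

Compound 4, `Clc1ccccc1CSc1nc(-c2ccc(Br)cc2)cc(-c2cccc(Br)c2)n1`, is not yet measured. It is built from compound 2 by a change of a different kind: 3-bromophenyl in place of 4-bromophenyl on an aromatic carbon. This alters one of the two bromophenyl groups and leaves the benzyl side untouched. Going by the values given here, none of the measured steps touches a bromophenyl group, so none bears directly on this exchange; what they do show is that the shared core of compound 2 has kept the same value through every change made around it so far. On that basis compound 4 is expected to stay close to compound 2, with no change at the digits printed from compound 2 to compound 4 (within the scatter), a step expected to lie within the scatter. The estimate for compound 4 in this assay is 19000 nM, in a range from 8000 nM to 45000 nM. The range is set wide; this part of the molecule has not been tested before.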

Compound 4, half-maximal inhibitory concentration: 19000 nM
Compound 4: middle estimate and measured number agree at the digits printed; low and high end bracket the measured number.
By their numbers in this assay, from the lowest: compounds 1, 2, 3 and 4 (each within the scatter of the next).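

Going by these compounds alone, until now, every step changed only the halogenated benzyl group on sulfur, so this is the first information about a bromophenyl group, here the one on the aromatic carbon next to the ring nitrogen. In this assay, 3-bromophenyl in place of 4-bromophenyl gives no change at the digits printed from compound 2 to compound 4 (within the scatter), so where the bromine sits on this ring makes no visible difference between these two compounds. No measurement here offers an explanation for this unchanged value.

From the compounds shown here alone, whether the other 4-bromophenyl group would respond in the same way remains open, as does the outcome of replacing the bromine on either ring with an amine or a carboxylic acid. Also unanswered is what a longer chain between the sulfur and the halogenated phenyl ring would do.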